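The compounds below may be only part of what the source reports. "The series", "measured", "known", "first", "only" and "open" are said of these compounds alone.

Measured in a functional assay on MKN-45 cells (Homo sapiens) for inhibition, read by CCK-8 assay, with a stated time of 24 h; a higher number here means a weaker inhibitor, a lower number a stronger inhibitor:
Compound 1 `O=C1Nc2ccccc2/C1=C/c1ccc(-c2cn(-c3cccc(F)c3)nn2)cc1`: > 20000 nM, a limit of the assay
Compound 2 `Cc1cccc(-n2cc(-c3ccc(/C=C4\C(=O)Nc5ccc(F)cc54)cc3)nn2)c1`: 6810 nM
Compound 3 `Cc1ccc(-n2cc(-c3ccc(/C=C4\C(=O)Nc5ccc(F)cc54)cc3)nn2)cc1`: 34600 nM

In this assay compound 3, at 34600 nM, carries the higher of the two actual numbers, and compound 2 lies lower at 6810 nM. The entry for compound 1 is a limit and not a number: > 20000 nM.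

The next compound is compound 4 `O=C1Nc2ccc(F)cc2/C1=C/c1ccc(-c2cn(-c3ccc(F)cc3)nn2)cc1`. Its difference from compound 3 is fluoro in place of methyl on an aromatic carbon. The change turns 4-methylphenyl into 4-fluorophenyl.

Among the compounds with values here, no measured step makes this exact change. The closest evidence is a 5.1-fold higher number from compound 2 to compound 3 (0.71 log units; beyond the scatter), which concerns the placing of the methyl and not its replacement. It suggests that a change on this ring can be modest in size, but it gives no direction here. Only a small move toward a lower number is expected, none clearly beyond the scatter. The estimated step is a 1.7-fold lower number from compound 3 to compound 4 (0.24 log units; within the scatter). For compound 4 the expected value is 20000 nM, with an estimated range of 6000 nM to 60000 nM.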

Compound 4, half-maximal inhibitory concentration: > 20000 nM
Compound 4 ended at the assay's limit; the forecaster's own chance of this, stated with the estimate: 35%; the middle value lies on the limit itself.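

In this assay compound 4 gives > 20000 nM, a limit of the assay, so the step from methyl to fluoro on this ring cannot be read: the limit of > 20000 nM in this assay, at which 2 of the 4 values shown sit. The change from 3-methylphenyl to 4-fluorophenyl can be read, as an at least 2.9-fold higher number from compound 2 to compound 4 (0.46 log units; beyond the scatter), and it points the same way as a 5.1-fold higher number from compound 2 to compound 3 (0.71 log units; beyond the scatter). So 4-fluorophenyl, like 4-methylphenyl, goes with a higher number than 3-methylphenyl, and fluoro at this position does not restore a readable value in the range of compound 2.

On these data alone, whether fluoro gives a higher or lower number than methyl at this position remains open. Also open, as far as these compounds go, is how an amine or a carboxylic acid would read at this position, or a fluoro group in the place the methyl holds in compound 2 on the fluorinated core.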